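Lengthening a Saturated Chain: Cytotoxicity Still at the Limit

A few compounds are considered here, and "the series" means these few. Any claim that something is new, unique, unknown or untested is made for them only; others in the source may bear on it.

compound 1, `CCCCCCCCCCCCCCCC1=NC(C)CCC1`: > 10 ug/mL
compound 2, `CCCCCCCCCCCCCCC1=NC(C)CCC1`: > 10 ug/mL

In an ADME assay on THP-1 cells (Homo sapiens) for cytotoxicity (on this read-out higher numbers stand for weaker inhibition and lower numbers for stronger inhibition), compound 1 gives > 10 ug/mL, which is a limit of the assay rather than a number. Compound 2 gives > 10 ug/mL in this assay, again a limit. Because both sit at a limit, the step that the two limits leave unreadable from compound 1 to compound 2 cannot be read. On the numbers shown, compound 2 stands at the limit of > 10 ug/mL in this assay, at which 2 of the 2 values shown sit.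

The unmeasured compound 3, `CCCCCCCCCCCCCCCCC1=NC(C)CCC1`, differs from compound 2 by ethyl in place of hydrogen on a saturated chain carbon, ten or more bonds along the chain from a carbon with a double bond to nitrogen. Within the data shown here, the only measured step, a step that the two limits leave unreadable from compound 1 to compound 2, is a change of the same kind on the same chain, and its size is unknown, so it offers no direction and no size to carry over. Nothing among the shown values points to a move off the limit for a change of this kind. Compound 3 is therefore expected to give 15 ug/mL in this assay, within a range from 7 ug/mL to 40 ug/mL. The step that the limit leaves unreadable from compound 2 to compound 3 is thus expected to be none beyond the scatter, with the assay most likely again reporting only a limit.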

Compound 3, half-maximal inhibitory concentration: > 10 ug/mL
Compound 3: a limit, no number; the forecaster's own chance of this, stated with the estimate: 85%; the middle value lies beyond the limit too.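

Compound 3 sits at a limit of the assay, as do compound 1 and compound 2, so no step among these three compounds can be read: the limit of > 10 ug/mL in this assay, at which 3 of the 3 values shown sit.

The compounds shown leave open what number any of them would give in this assay, and whether the length of the saturated chain changes that number at all.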